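Swapping the dichlorophenyl pattern on a shared core

The compounds below may be only part of what the source reports. "The series", "measured", "known", "first", "only" and "open" are said of these compounds alone.

All values below come from a functional assay on HT-1080 cells (Homo sapiens) for cytotoxicity, read by MTT assay, with a stated time of 72 h; a higher number here means a weaker inhibitor, a lower number a stronger inhibitor.

Compound 1 `COc1cccc(/C=C2\CCC/C(=C\c3cccc(Cl)c3Cl)C2=O)c1OC`: 19300 nM
Compound 2 `COc1cccc(/C=C2\CCC/C(=C\c3ccc(Cl)cc3Cl)C2=O)c1OC`: > 20000 nM, which is a limit of the measurement rather than a number
Compound 3 `COc1ccc(/C=C2\CCC/C(=C\c3cccc(Cl)c3Cl)C2=O)cc1OC`: 8800 nM

Compounds 1 and 3 share most of their structure; how their two cores differ is not broken down here. What their values show is that compound 3 gives a lower number than compound 1 in this assay, a gap beyond the usual scatter. Compound 2 is compound 1 with 2,4-dichlorophenyl in place of 2,3-dichlorophenyl on a double-bonded chain carbon bound to a double-bonded ring carbon. That change gave an at least 1.0-fold higher number from compound 1 to compound 2 (0.01 log units; that floor lies within the scatter). Compound 2 sits at the limit of > 20000 nM in this assay, at which 1 of the 3 values shown sits, so the full size of that step is not known, only its floor.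

Compound 4 `COc1ccc(/C=C2\CCC/C(=C\c3ccc(Cl)cc3Cl)C2=O)cc1OC` has not yet been measured. It stands to compound 3 exactly as compound 2 stands to compound 1: 2,4-dichlorophenyl in place of 2,3-dichlorophenyl on a double-bonded chain carbon bound to a double-bonded ring carbon. The change is made at the same place in both pairs, so it is the same change. Because the earlier change gave an at least 1.0-fold higher number from compound 1 to compound 2 (0.01 log units; that floor lies within the scatter), a step in the same direction, and of at least the same size, is expected here, a 2.0-fold higher number from compound 3 to compound 4 (0.31 log units; beyond the scatter). Compound 4 is therefore estimated to give about 18000 nM in this assay, most likely between 9000 nM and 40000 nM, and there is a real chance that only a limit is reported for it.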

Compound 4, half-maximal inhibitory concentration: 10500 nM
Estimate against measurement, compound 4: 1.7-fold (0.23 log units) above, within the range that was stated.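

On the second core, 2,4-dichlorophenyl in place of 2,3-dichlorophenyl on a double-bonded chain carbon bound to a double-bonded ring carbon gave a 1.2-fold higher number from compound 3 to compound 4 (0.08 log units; within the scatter) in this assay, so on this core the swap leaves no difference that can be told from ordinary repeat variation. Set beside the same swap on the first core, this result neither shows that the change carries over with the same size nor shows that its size depends on the core, and the comparison stands as follows: the same change on two cores in this assay, an at least 1.0-fold higher number (0.01 log units; that floor lies within the scatter) from compound 1 to compound 2 and a 1.2-fold higher number (0.08 log units; within the scatter) from compound 3 to compound 4; the limit leaves it open whether they differ. Compound 2 is reported only as a limit, > 20000 nM, so the step on the first core has a floor but no measured size, and one clear pair plus one open-ended pair cannot establish a rule for this series.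

The compounds shown leave open whether a phenyl ring with a single chlorine, or one carrying a nitrile or an amine in place of the two chlorines, would shift the number in this assay by more than the scatter. They also leave open how the swap would behave on any core beyond these two, and what the step on the first core would be if compound 2 had a measured value.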